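Replacing Fluoro with Isopropyl on the Core of Compound 2

The source may hold more compounds than are shown below. What is called first, only, known or untested is meant among the compounds shown, and "the series" means these compounds.

Compound 1 `COc1cccc(/C=C/c2ccc(F)cc2)c1` gives 6000 nM in an assay on HepG2 cells for activation of nuclear factor erythroid 2-related factor 2 (Homo sapiens), read by a luciferase reporter, with a stated time of 5 h; on this read-out higher numbers stand for an effect only at larger amounts of compound and lower numbers for an effect already at smaller amounts. Among the compounds with values here, compound 2 `COc1cccc(/C=C/c2ccc(F)cc2)c1OC` gives 2900 nM, the lower of the two numbers measured so far, because the step from compound 1 to compound 2 was a 2.1-fold lower number from compound 1 to compound 2 (0.32 log units; beyond the scatter). Compound 3 `COc1cccc(/C=C/c2ccc(C(C)C)cc2)c1OC` differs from compound 2 by isopropyl in place of fluoro on an aromatic carbon. Within the data shown here, that single measured step concerns a methoxy group on a different carbon, so no measured step bears on this change. The step from compound 2 to compound 3 is therefore expected to be a 1.2-fold lower number from compound 2 to compound 3 (0.06 log units; within the scatter), nothing beyond the scatter. Compound 3 is estimated at 2500 nM, within 600 nM to 10000 nM.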

Compound 3, half-maximal effective concentration: 2700 nM
Beside the measured number, compound 3's estimate is 1.1-fold (0.03 log units) below it, and the stated range covers the measured number.
By their numbers in this assay, from the lowest: compounds 3 and 2 (each within the scatter of the next); then compound 1.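

At this position, on an aromatic carbon para to a large group, isopropyl can stand in place of fluoro with no change beyond the scatter (a 1.1-fold lower number from compound 2 to compound 3 (0.03 log units; within the scatter)). Within the data shown here, the earlier step concerned only a methoxy group on a different carbon, so this is the first reading at this position, and going from 1 heavy atom to 3 leaves the number in the same range. No available evidence explains this result. From the compounds shown here alone, whether an amine or a carboxylic acid here would behave the same remains open. So does the effect of a longer chain.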